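The source may hold more compounds than are shown below. What is called first, only, known or untested is meant among the compounds shown, and "the series" means these compounds.

Compound 1 `O=C(CCCCN1CCCCC1)Nc1cc(-c2ccco2)n[nH]1` gives > 10 10^-6 cm/s in an ADME assay for permeability, using PAMPA, with a stated time of 4 h, tested at 10 uM (a higher number here means that the compound crosses the layer faster, a lower number that the compound crosses the layer more slowly), which is a limit of the assay and not a number. Compound 2 `O=C(CCCCN1CCCCC1)Nc1cc(-c2ccc(Cl)cc2)n[nH]1` gives > 10 10^-6 cm/s in this assay, again a limit. For the measured compounds named here, the series so far stands at the limit of > 10 10^-6 cm/s in this assay, at which 2 of the 2 values shown sit, so compound 1 has no exact position on the scale.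

Compound 3 `COc1cccc(-c2cc(NC(=O)CCCCN3CCCCC3)[nH]n2)c1` differs from compound 1 by 3-methoxyphenyl in place of furan-2-yl on an aromatic carbon. Going by the values given here, one measured step bears on this change, at the same aromatic carbon: a step that the two limits leave unreadable from compound 1 to compound 2. It has no readable size, and the six-membered aromatic ring of carbon only left the read-out at the limit. Compound 3 carries the same ring type, so on that single step no change beyond the scatter is expected in this assay, and no direction can be favoured. The expected step is a step that the limit leaves unreadable from compound 1 to compound 3. For compound 3 the estimate is 15 10^-6 cm/s, with an expected range from 8 10^-6 cm/s to 30 10^-6 cm/s, and a report as a limit is again the likelier outcome.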

Compound 3, apparent permeability: > 10 10^-6 cm/s
Compound 3 gave a limit, no number (the forecaster's own chance of this, stated with the estimate: 70%); the middle value is on the limit's open side.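

No step among compound 1, compound 2 and compound 3 can be read in this assay, since each result is a limit of the assay and not a number: the limit of > 10 10^-6 cm/s in this assay, at which 3 of the 3 values shown sit.

The compounds shown leave open how far apart these three lie on the scale, and whether furan-2-yl, 4-chlorophenyl and 3-methoxyphenyl differ at all in the read-out.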